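Swapping an ester tail for a long hydroxyalkyl chain

A few compounds are considered here, and "the series" means these few. Any claim that something is new, unique, unknown or untested is made for them only; others in the source may bear on it.

Measured so far in an assay (Cricetulus griseus) for inhibition of aldehyde dehydrogenase, mitochondrial (Homo sapiens); a lower number here means a stronger inhibitor, a higher number a weaker inhibitor:
- compound 1 `CCOC(=O)CCCCCOc1ccc2c(=O)c(-c3ccc(O)cc3)coc2c1` gives 280 nM
- compound 2 `CC(Oc1ccc2c(=O)c(-c3ccc(O)cc3)coc2c1)C(=O)O` gives 2500 nM
- compound 3 `CCCCC(Oc1ccc2c(=O)c(-c3ccc(O)cc3)coc2c1)C(=O)OCC` gives 4500 nM

Among these three, compound 1 gives the lowest number, and both of the others lie beyond the usual scatter from it, so compound 1 is the strongest inhibitor of the set. Compound 2 carries an acid on a short branched chain and compound 3 an ester on a longer branched chain; both give clearly higher numbers than compound 1, though neither differs from it in a single place, so what their values show is only that these two variants are weaker.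

Compound 4 `O=c1c(-c2ccc(O)cc2)coc2cc(OCCCCCCCCCCCCO)ccc12` has not yet been measured. It differs from compound 1 in one place: 7-hydroxyheptyl in place of ethoxycarbonyl on a saturated chain carbon, five bonds along the chain from an oxygen on an aromatic ring. The ester end is gone and a much longer chain ending in a hydroxyl stands in its place. Among the measured compounds shown here, no measured pair reports such a change, so the expected size of the step is uncertain. A modest weakening, around the edge of the scatter, is expected: a 1.6-fold higher number from compound 1 to compound 4 (0.21 log units; within the scatter). Compound 4 is therefore estimated at 450 nM in this assay, within a range of 120 nM to 1800 nM.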

Compound 4, half-maximal inhibitory concentration: 1700 nM
Compound 4: middle estimate off by 3.8-fold (0.58 log units), on the low side; the measured number falls inside the stated range.
By their numbers in this assay, from the lowest: compound 1; then compounds 4, 2 and 3 (each within the scatter of the next, the first and the last beyond it).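

In this assay, among the compounds shown here, the step of a 6.1-fold higher number from compound 1 to compound 4 (0.78 log units; beyond the scatter) is the first comparison in this set between two compounds that differ in only one place. It shows that the end of the chain at this position, on a saturated chain carbon five bonds along the chain from an oxygen on an aromatic ring, does affect the result. Putting 7-hydroxyheptyl in place of ethoxycarbonyl weakens inhibition beyond the usual scatter of repeated measurements, although compound 4 still gives a measurable value. No measurement is available to explain why the number rises.

The compounds shown leave open which part of this swap matters, as losing the ester, lengthening the chain and adding a terminal hydroxyl all occur together in this single step. A shorter hydroxyalkyl chain, or an amine or primary amide at the end of the long chain, would help to pull these parts apart and show whether the hydroxyl itself or the added chain length goes with the weaker inhibition.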